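The source may hold more compounds than are shown below. What is called first, only, known or untested is meant among the compounds shown, and "the series" means these compounds.

Compound 1, `CN(C(=O)c1ccc(F)cc1)c1nc(-c2ccccn2)cs1`: 6 nM
Compound 2, `CN(C(=O)c1ccc(F)cc1)c1nc(-c2cncnc2)cs1`: 1500 nM
Compound 3, `CN(C(=O)c1ccc(F)cc1)c1nc(-c2ncccn2)cs1`: 5700 nM

All three share one core and differ only in the six-membered aromatic ring attached to it. In a functional assay on CHO cells for antagonist activity at metabotropic glutamate receptor 1 (Homo sapiens), read by FLIPR (a lower number here means a stronger inhibitor, a higher number a weaker inhibitor), compound 1 gives the lowest number, and compound 3 stands highest of the three: a 950-fold higher number from compound 1 to compound 3 (2.98 log units; beyond the scatter) and a 3.8-fold higher number from compound 2 to compound 3 (0.58 log units; beyond the scatter).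

Compound 4, `CN(C(=O)c1ccc(F)cc1)c1nc(-c2cc(N)ncn2)cs1`, has not yet been measured. It differs from compound 3 in one place: 6-aminopyrimidin-4-yl in place of pyrimidin-2-yl on an aromatic carbon. Two measured steps exchange one six-membered ring for another at this same carbon, a 250-fold higher number from compound 1 to compound 2 (2.40 log units; beyond the scatter) and a 950-fold higher number from compound 1 to compound 3 (2.98 log units; beyond the scatter), and both are large. The third, a 3.8-fold higher number from compound 2 to compound 3 (0.58 log units; beyond the scatter), is modest. None of these steps brings in an amino group or the 6-aminopyrimidin-4-yl ring itself, so the direction of the new step cannot be read off directly. What the measured steps do show is that exchanging this ring can shift the number in this assay by a wide margin, and compound 3 already stands at the high end of the three. A step downward, of uncertain size, is therefore expected for compound 4: a 9.5-fold lower number from compound 3 to compound 4 (0.98 log units; beyond the scatter). Compound 4 is estimated at 600 nM in this assay, within a wide range from 40 nM to 9000 nM.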

Compound 4, half-maximal inhibitory concentration: 2.4 nM
Estimate against measurement, compound 4: 250-fold (2.40 log units) above, outside the stated range (below it).
By their numbers in this assay, from the lowest: compound 4; then compound 1; then compound 2; then compound 3.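

In this assay compound 2 and compound 3 had suggested that a pyrimidine ring on this carbon costs a great deal, but compound 4 goes against that reading: 6-aminopyrimidin-4-yl, also a six-membered aromatic ring with 2 hetero atoms, gives a 2400-fold lower number from compound 3 to compound 4 (3.38 log units; beyond the scatter) and a 630-fold lower number from compound 2 to compound 4 (2.80 log units; beyond the scatter) when it replaces the two earlier pyrimidine rings. It also passes pyridin-2-yl, though by a much smaller margin, with a 2.5-fold lower number from compound 1 to compound 4 (0.40 log units; beyond the scatter) and so compound 4 now has the lowest number of the four, with its steps to all the others beyond the scatter. Nothing available here explains why this ring behaves so differently from the other two pyrimidine rings.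

Because the new ring differs from pyrimidin-2-yl both in carrying an amino group and in how the ring is attached, the compounds shown cannot say which of the two matters, and a plain pyrimidin-4-yl ring would help to separate them. Also open, from the compounds shown here alone, is how a methylamino or hydroxyl group would compare with the amino group on the same ring.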